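Metabolic stability of benzylsulfanyl sulfonylguanidines: a chloro swap

A few compounds are considered here, and "the series" means these few. Any claim that something is new, unique, unknown or untested is made for them only; others in the source may bear on it.

Measured compounds:
Compound 1, `Cc1cccc(CSc2cc(Cl)c(C)cc2S(=O)(=O)/N=C(\N)n2nccc2-c2ccccc2)c1`, gives 0.232 h in an ADME assay on microsomes from liver (Homo sapiens) for metabolic stability, read by LC-MS, using NADPH, tested at 5 uM; a lower number here means that the compound disappears faster, a higher number that the compound lasts longer.
Compound 2, `Cc1cc(S(=O)(=O)/N=C(\N)n2nccc2-c2ccccc2)c(SCc2cccc(Cl)c2)cc1Cl`, gives 0.309 h in this assay.
Compound 3, `Cc1ccc(CSc2cc(Cl)c(C)cc2S(=O)(=O)/N=C(\N)n2nccc2-c2ccccc2)cc1`, gives 0.13 h in this assay.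

Compound 3 holds the lowest of the three numbers. Its step from compound 2 is a 2.4-fold lower number from compound 2 to compound 3 (0.38 log units; beyond the scatter), whereas its step from compound 1 is a 1.8-fold lower number from compound 1 to compound 3 (0.25 log units; within the scatter), so only the gap to compound 2 lies beyond the scatter.

Compound 4, `Cc1cc(S(=O)(=O)/N=C(\N)n2nccc2-c2ccccc2)c(SCc2ccccc2Cl)cc1Cl`, differs from compound 3 by 2-chlorophenyl in place of 4-methylphenyl on a saturated chain carbon bound to a sulfur. For the measured compounds named here, two measured steps touch the same place. The step of a 2.4-fold lower number from compound 2 to compound 3 (0.38 log units; beyond the scatter) exchanged a chlorophenyl for the methylphenyl and lowered the number, and the step of a 1.8-fold lower number from compound 1 to compound 3 (0.25 log units; within the scatter) moved a methyl around the ring with a smaller effect. Elsewhere, the step of a 1.3-fold higher number from compound 1 to compound 2 (0.12 log units; within the scatter) put chloro in place of methyl without leaving the scatter. Returning to a chlorophenyl, now 2-chlorophenyl, is therefore expected to bring a modest rise, roughly undoing the step from compound 2, so the expected step is a 1.9-fold higher number from compound 3 to compound 4 (0.28 log units; within the scatter). Compound 4 is estimated at 0.25 h, with a range from 0.12 h to 0.5 h.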

Compound 4, half-life: 0.226 h
Compound 4: the middle estimate sits 1.1-fold (0.04 log units) above what was measured; the measured number falls inside the stated range.
By their numbers in this assay, from the lowest: compounds 3, 4, 1 and 2 (each within the scatter of the next, the first and the last beyond it).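

In this assay, the 2-chlorophenyl on the saturated chain carbon bound to a sulfur stays within the scatter of all three earlier groups (a 1.7-fold higher number from compound 3 to compound 4 (0.24 log units; within the scatter); a 1.4-fold lower number from compound 2 to compound 4 (0.14 log units; within the scatter); a 1.0-fold lower number from compound 1 to compound 4 (0.01 log units; within the scatter)). Compound 4 therefore shows that a chlorophenyl at this place need not stand beyond the scatter from the 4-methylphenyl of compound 3, so the one gap beyond the scatter remains that between compound 2 and compound 3. Nothing in the data shown explains these numbers.

On these data alone, what remains open is whether 4-chlorophenyl or 2-methylphenyl would stay within the same scatter. As far as these compounds go, it is also open whether a methoxy group, an amine or a carboxylic acid on this phenyl ring would move the half-life clearly beyond it.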